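Swapping a methylbenzyl for a difluorobenzyl on a xanthine

The compounds below may be only part of what the source reports. "The series", "measured", "known", "first", "only" and "open" are said of these compounds alone.

Compound 3 `CCCn1c(=O)c2nc(-c3cnn(Cc4cccc(C)c4)c3)[nH]c2n(CCC)c1=O` is the reference point of this short series. In an in vitro assay on HEK293 cells for displacement of a labelled ligand from adenosine receptor A2b (Homo sapiens) (a lower number here means a stronger inhibitor, a higher number a weaker inhibitor), compound 3 gives 36 nM, the lowest of the two numbers recorded. Compound 1 `CC(C)Cn1c(=O)c2nc(-c3cnn(Cc4cccc(F)c4)c3)[nH]c2n(CC(C)C)c1=O` differs from compound 3 in several positions. In this assay compound 1 gives 990 nM, a far weaker result. Compound 2 `CCCn1c(=O)c2nc(-c3cnn(-c4ccccc4)c3C(F)(F)F)[nH]c2n(CCC)c1=O` does not yield a number at all: in this assay compound 2 reaches only the limit of > 6600 nM, which is the assay limit noted as the limit of > 6600 nM in this assay, at which 1 of the 3 values shown sits.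

Compound 4 `CCCn1c(=O)c2nc(-c3cnn(Cc4cccc(F)c4F)c3)[nH]c2n(CCC)c1=O` is not yet measured. Compared with compound 3 the change is 2,3-difluorophenyl in place of 3-methylphenyl on a saturated chain carbon bound to an aromatic nitrogen. Among the compounds with values here, in the measured pairs no single-point comparison exists for this kind of change, so there is no direct precedent to lean on. Both of the other members sit well below compound 3 in strength, and a substituent swap on the benzyl ring is expected to cost some binding, roughly a 4.2-fold higher number from compound 3 to compound 4 (0.62 log units; beyond the scatter). Compound 4 is therefore estimated at 150 nM in this assay, within a range from 40 nM to 600 nM.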

Compound 4, inhibition constant: 240 nM
Compound 4: middle estimate off by 1.6-fold (0.20 log units), on the low side, within the range that was stated.
By their numbers in this assay, from the lowest: compound 3; then compound 4; then compound 1. At a limit, above all of these: compound 2.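

Within the data shown here, this is the first comparison where only one place changes, and it shows that the group on the saturated chain carbon bound to an aromatic nitrogen affects binding. In this assay, putting 2,3-difluorophenyl in place of 3-methylphenyl gives a 6.7-fold higher number from compound 3 to compound 4 (0.82 log units; beyond the scatter), a modest step that lies beyond the scatter, so this position tolerates the swap but at a measurable cost. Nothing in the data shown bears on the reason for this rise.

The swap removes a methyl and adds two fluorines in one step, so the compounds shown cannot separate the effect of losing the methyl from that of adding the fluorines. From the compounds shown here alone, it also remains open whether an amine or a carboxylic acid on this ring would bring the number closer to that of compound 3 (36 nM).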